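Sulfonyl aryl swap: compound 1 to compound 4

The source may hold more compounds than are shown below. What is called first, only, known or untested is meant among the compounds shown, and "the series" means these compounds.

Measured so far:
compound 1 `Cc1noc(C)c1S(=O)(=O)N1CCC(N2CCC(C)CC2)CC1` — > 5000 nM
compound 2 `CCc1cc(Br)ccc1S(=O)(=O)N1CCC(N2CCC(C)CC2)CC1` — 0.6 nM
compound 3 `Cc1cc(C)c(S(=O)(=O)NC2CCN(C3CCN(C)CC3)CC2)c(C)c1` — 958 nM

In a functional assay on DLD-1 cells (Homo sapiens) for antiproliferative activity, read by CellTiter-Glo, with a stated time of 72 h (on this read-out higher numbers stand for weaker inhibition and lower numbers for stronger inhibition), compound 1 gives only a limit of the assay, > 5000 nM, and so stands at the limit of > 5000 nM in this assay, at which 1 of the 3 values shown sits. Compound 2 gives 0.6 nM and compound 3 gives 958 nM; no step between measured compounds differing in one place is shown, so these are read side by side only. Compound 4 `CC1CCN(C2CCN(S(=O)(=O)c3ccc(F)cc3F)CC2)CC1` awaits measurement. It differs from compound 1 by 2,4-difluorophenyl in place of 3,5-dimethyl-1,2-oxazol-4-yl on a sulfonyl sulfur. Compound 2, which carries a six-membered aromatic ring of carbon only on the sulfonyl sulfur, sits at 0.6 nM. A step toward stronger inhibition, beyond the scatter, is therefore expected, an at least 100-fold lower number from compound 1 to compound 4 (2.00 log units; beyond the scatter). Compound 4 is estimated at 50 nM, within 5 nM to 800 nM.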

Compound 4, half-maximal inhibitory concentration: 102 nM
Compound 4: the middle estimate sits 2.0-fold (0.31 log units) below what was measured; measured number inside the range.
By their numbers in this assay, from the lowest: compound 2; then compound 4; then compound 3. At a limit, above all of these: compound 1.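

Within the data shown here, on the sulfonyl sulfur, 2,4-difluorophenyl in place of 3,5-dimethyl-1,2-oxazol-4-yl gives an at least 49-fold lower number from compound 1 to compound 4 (1.69 log units; beyond the scatter) in this assay, the first direct reading of this position. The group at this place alone therefore carries a large change, with the rest of the core of compound 1 held fixed. The size of the step is only a bound, because compound 1 stands at a limit of the assay: the limit of > 5000 nM in this assay, at which 1 of the 4 values shown sits.

As far as these compounds go, whether the change comes from the two fluorines or from the carbon-only six-membered ring itself stays open. An unsubstituted phenyl or a pyridine ring on the sulfonyl sulfur would separate the two.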